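Benzyl for pyridyl on the acrylamide chain

A few compounds are considered here, and "the series" means these few. Any claim that something is new, unique, unknown or untested is made for them only; others in the source may bear on it.

Measured compounds:
compound 1 `CC(C)(C)c1ccc(CCC(=O)Nc2ccc3c(c2)OCCO3)cc1` — 660 nM
compound 2 `CC(C)(C)c1ccc(C2CC2C(=O)Nc2ccc3c(c2)OCCO3)cc1` — > 4000 nM
compound 3 `CC(C)(C)c1ccc(/C(=C/C(=O)Nc2ccc3c(c2)OCCO3)c2cccnc2)cc1` — 510 nM

In a functional assay on CHO cells for inhibition of transient receptor potential cation channel subfamily V member 1 (Homo sapiens) (on this read-out higher numbers stand for weaker inhibition and lower numbers for stronger inhibition), compound 3 gives 510 nM. Compound 1 gives 660 nM, a number within the scatter of that of compound 3, so the two cannot be ranked against each other. For compound 2 the value is a limit of the assay (the limit of > 4000 nM in this assay, at which 1 of the 3 values shown sits), not a number. Compound 4 `CC(C)(C)c1ccc(/C(=C/C(=O)Nc2ccc3c(c2)OCCO3)Cc2ccccc2)cc1` differs from compound 3 in one place: benzyl in place of pyridin-3-yl on a double-bonded chain carbon bound to an aromatic carbon and a double-bonded chain carbon. Among the measured compounds shown here, no measured pair shows this kind of exchange, so its effect is open. A modest change, in either direction or none beyond the scatter, is expected from compound 3 to compound 4, that is a 1.5-fold higher number from compound 3 to compound 4 (0.17 log units; within the scatter). Compound 4 is therefore estimated at 750 nM, with a range from 200 nM to 2800 nM.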

Compound 4, half-maximal inhibitory concentration: 110 nM
For compound 4 the middle estimate is 6.8-fold (0.83 log units) above the measured one; measured number below the stated range.
By their numbers in this assay, from the lowest: compound 4; then compounds 3 and 1 (each within the scatter of the next). At a limit, above all of these: compound 2.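

Among the compounds shown here, the exchange of pyridin-3-yl for benzyl on this double-bonded chain carbon gives a 4.6-fold lower number from compound 3 to compound 4 (0.67 log units; beyond the scatter), so inhibition here depends on the group carried at this place, something no earlier pair could show. Benzyl brings a ring of carbon only and no hydrogen-bond acceptor, but this single exchange cannot separate those differences from the change in group size. Nothing measured here gives a cause for this step.

The compounds shown leave open how a plain phenyl or a longer chain such as 2-phenylethyl would fare at this carbon. They also leave open whether an amine on the benzyl ring would keep the stronger inhibition.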